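Tertiary amide variant of a pyrazole HMG-CoA reductase inhibitor

This account rests on a few compounds, and the source may have more. Where it says the series, first, only, none or still open, it means among the compounds named here.

Compound 2 `CC(C)c1c(C(=O)NCc2cccc(Cl)c2)nn(-c2ccc(F)cc2)c1OC[C@@H](O)C[C@@H](O)CC(=O)O` holds the lowest number of the two measured in an assay on microsomes from liver for inhibition of 3-hydroxy-3-methylglutaryl-coenzyme A reductase (Rattus norvegicus) (on this read-out lower numbers stand for stronger inhibition and higher numbers for weaker inhibition), where compound 2 gives 5.4 nM; compound 1 `CC(C)c1c(C(=O)N2CCCCC2)nn(-c2ccc(F)cc2)c1OC[C@@H](O)C[C@@H](O)CC(=O)O` gives 47 nM. Compound 3 `Cc1cccc(CN(C)C(=O)c2nn(-c3ccc(F)cc3)c(OC[C@@H](O)C[C@@H](O)CC(=O)O)c2C(C)C)c1` carries methyl(3-methylbenzyl)amino in place of (3-chlorobenzyl)amino on a carbonyl carbon. For the measured compounds named here, the only measured step, an 8.7-fold lower number from compound 1 to compound 2 (0.94 log units; beyond the scatter), moved from a tertiary amide to the secondary benzylamide, and compound 3 returns to a tertiary amide. This suggests a step toward a higher number is expected, a 3.7-fold higher number from compound 2 to compound 3 (0.57 log units; beyond the scatter), though a different amine enters. For compound 3 the estimate in this assay is 20 nM, within a range of 5 nM to 80 nM.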

Compound 3, half-maximal inhibitory concentration: 37 nM
Compound 3: middle estimate off by 1.9-fold (0.27 log units), on the low side, within the range that was stated.
By their numbers in this assay, from the lowest: compound 2; then compounds 3 and 1 (each within the scatter of the next).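

On the carbonyl carbon, methyl(3-methylbenzyl)amino in place of (3-chlorobenzyl)amino gives a 6.9-fold higher number from compound 2 to compound 3 (0.84 log units; beyond the scatter) in this assay, so a benzyl group on the amide nitrogen does not by itself keep the low number of compound 2. Against piperidin-1-yl the change reads a 1.3-fold lower number from compound 1 to compound 3 (0.10 log units; within the scatter), which puts these two tertiary amides level while compound 2, with its amide hydrogen, stands apart from both. Nothing given here explains this. The step alters the nitrogen substituent and the ring substituent together, so their shares cannot be separated. Methyl(3-chlorobenzyl)amino or (3-methylbenzyl)amino would each isolate one of the two changes.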